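Swapping Trifluoromethyl for Methoxy on the Amide Ring

This account rests on a few compounds, and the source may have more. Where it says the series, first, only, none or still open, it means among the compounds named here.

Three amides built on one shared core have been tested in an assay on LtK cells with ATP-sensitive inward rectifier potassium channel 11 (Homo sapiens) as the target; on this read-out lower numbers stand for an effect already at smaller amounts and higher numbers for an effect only at larger amounts of compound. Compound 1 `O=C(Nc1c(C(O)(C(F)(F)F)C(F)(F)F)ccc2ccccc12)c1cccc(C(F)(F)F)c1` gives 84 nM. Compound 2 `COc1cccc(C(=O)Nc2c(C(O)(C(F)(F)F)C(F)(F)F)ccc3ccccc23)c1` carries methoxy in place of trifluoromethyl on an aromatic carbon and gives 185 nM; on that change a 2.2-fold higher number from compound 1 to compound 2 (0.34 log units; beyond the scatter). Compound 3 `O=C(Nc1c(C(O)(C(F)(F)F)C(F)(F)F)ccc2ccccc12)c1ccc(C(F)(F)F)cc1` differs from compound 1 in the core by 4-(trifluoromethyl)phenyl in place of 3-(trifluoromethyl)phenyl on a carbonyl carbon. Compound 3 gives 160 nM; here a 1.9-fold higher number from compound 1 to compound 3 (0.28 log units; within the scatter), and the value of compound 3 sits close to that of compound 2.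

Compound 4 `COc1ccc(C(=O)Nc2c(C(O)(C(F)(F)F)C(F)(F)F)ccc3ccccc23)cc1` is not yet measured. It differs from compound 3 by methoxy in place of trifluoromethyl on an aromatic carbon. Within the data shown here, this is the same kind of change as the one from compound 1 to compound 2, but not the same: in compound 2 the methoxy sits meta to a large group, in compound 4 it sits para to a large group. Among the measured compounds shown here, only one earlier example of this kind of change is available, so the expectation rests on it alone. Because that example gave a 2.2-fold higher number from compound 1 to compound 2 (0.34 log units; beyond the scatter), a step of similar direction, a 2.1-fold higher number from compound 3 to compound 4 (0.31 log units; beyond the scatter), is expected here. Compound 4 is therefore estimated at 330 nM, with a likely range from 150 nM to 750 nM.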

Compound 4, half-maximal effective concentration: 417 nM
Compound 4: the middle estimate sits 1.3-fold (0.10 log units) below what was measured, within the range that was stated.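

In this assay, methoxy in place of trifluoromethyl now has a second example, a 2.6-fold higher number from compound 3 to compound 4 (0.42 log units; beyond the scatter), and it agrees with the first: the same change on two cores in this assay, a 2.2-fold higher number (0.34 log units; beyond the scatter) from compound 1 to compound 2 and a 2.6-fold higher number (0.42 log units; beyond the scatter) from compound 3 to compound 4, 1.2-fold (0.07 log units) apart, within the scatter of two such steps. Among the two methoxy amides, 4-methoxyphenyl in place of 3-methoxyphenyl also matters, with a 2.3-fold higher number from compound 2 to compound 4 (0.35 log units; beyond the scatter), and 4-methoxyphenyl in place of 3-(trifluoromethyl)phenyl gives the largest step of the set, a 5.0-fold higher number from compound 1 to compound 4 (0.70 log units; beyond the scatter). So the swap carried over between these two amides with much the same size, but two examples on closely related compounds do not show that it would do so on a different core, and they do not explain why the number rises.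

The compounds shown leave open whether other groups on the amide ring, such as a chlorine, a nitrile or an amine, would fall in line with these results. Also open, as far as these compounds go, is what a carboxylic acid or a longer chain such as ethoxy would do at the same place.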